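This account rests on a few compounds, and the source may have more. Where it says the series, first, only, none or still open, it means among the compounds named here.

Measured compounds and their results:

Compound 1 `CCNC(=O)c1noc(-c2cc(C(C)C)c(O)cc2O)c1-c1cc(CO)no1`: 5 nM
Compound 2 `CCNC(=O)c1noc(-c2cc(C(C)C)c(O)cc2O)c1-c1cc(C(=O)OCC)no1`: 9000 nM
Compound 3 `CCNC(=O)c1noc(-c2cc(C(C)C)c(O)cc2O)c1-c1ccn(C(C)C)n1`: 45 nM

In a functional assay on A2780 cells (Homo sapiens) for inhibition (on this read-out lower numbers stand for stronger inhibition and higher numbers for weaker inhibition), compound 1 gives the lowest of the three numbers. Its nearest neighbour is compound 3, reached by a 9.0-fold higher number from compound 1 to compound 3 (0.95 log units; beyond the scatter), and its furthest is compound 2, reached by a 1800-fold higher number from compound 1 to compound 2 (3.26 log units; beyond the scatter). Compound 4 `CCNC(=O)c1noc(-c2cc(C(C)C)c(O)cc2O)c1-c1cn[nH]c1` has not yet been measured. Compared with compound 1 it differs in one place: 1H-pyrazol-4-yl in place of 3-(hydroxymethyl)-1,2-oxazol-5-yl on an aromatic carbon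

Within the data shown here, two measured steps bear on this change, since both alter the same ring group on the shared core. The step from compound 1 to compound 3, which swaps the whole ring group for a different one, was modest. The step from compound 1 to compound 2, which only changes the substituent on that ring, was large. The change to compound 4 is a swap of the whole ring group, as in compound 3, so a modest rise in number in this assay is expected, not a large one. Compound 4 is therefore estimated at 30 nM, with a range from 6 nM to 200 nM, which means an expected step of a 6.0-fold higher number from compound 1 to compound 4 (0.78 log units; beyond the scatter).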

Compound 4, half-maximal inhibitory concentration: 38 nM
For compound 4 the middle estimate is 1.3-fold (0.10 log units) below the measured one; the measured number falls inside the stated range.
By their numbers in this assay, from the lowest: compound 1; then compounds 4 and 3 (each within the scatter of the next); then compound 2.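

In this assay, putting 1H-pyrazol-4-yl in place of 3-(hydroxymethyl)-1,2-oxazol-5-yl gives a 7.6-fold higher number from compound 1 to compound 4 (0.88 log units; beyond the scatter), so this position accepts a different ring with no side group at only a modest loss. The two pyrazole groups cannot be told apart, with a 1.2-fold lower number from compound 3 to compound 4 (0.07 log units; within the scatter), which shows that an unsubstituted ring does as well here as one carrying an isopropyl group, and the unsubstituted ring also stands far from the ester-bearing ring, with a 240-fold lower number from compound 2 to compound 4 (2.37 log units; beyond the scatter). No measurement offered here explains these differences.

Still open, from the compounds shown here alone, is whether the hydroxymethyl group or the 1,2-oxazole ring matters more for the low number of compound 1, a question that a pyrazole carrying hydroxymethyl could help to separate. Also open, going by these compounds, is where a carboxylic acid, an amine or a longer hydroxyalkyl chain on this ring would fall.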